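The source may report more compounds than this note shows. Statements on the series, on what has been measured and on what is new or still open speak of the compounds shown alone.

Of the compounds shown here, two sharing one core have been tested so far in a functional assay on aorta (Rattus norvegicus, strain Sprague-Dawley) for inhibition; a higher number here means that more compound is needed for the effect, a lower number that less compound is needed. Compound 1 `CCCCCCOc1cc2c(c3c1C[C@@H]1[C@@H](C)CO[C@]1(C)O3)C[C@@H]1[C@@H](C)CO[C@]1(C)O2` gives > 200000 nM, which is a limit of the assay and not a number. Among the measured compounds shown here, compound 2 `C#CCOc1cc2c(c3c1C[C@@H]1[C@@H](C)CO[C@]1(C)O3)C[C@@H]1[C@@H](C)CO[C@]1(C)O2` gives 23000 nM, the only true number available, so it is the single firm reference point here.

The next compound, compound 3 `COc1cc2c(c3c1C[C@@H]1[C@@H](C)CO[C@]1(C)O3)C[C@@H]1[C@@H](C)CO[C@]1(C)O2`, has hydrogen in place of ethynyl on a saturated chain carbon bound to an oxygen on an aromatic ring, which turns propargyloxy into methoxy: hydrogen in place of ethynyl on a saturated chain carbon bound to an oxygen on an aromatic ring.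

For the measured compounds named here, only one measured step changes this same place, an at least 8.6-fold lower number from compound 1 to compound 2 (0.93 log units; beyond the scatter), where ethynyl stands in place of pentyl. As far as these compounds go, its true size is unknown, since it starts from the limit of > 200000 nM in this assay, at which 1 of the 2 values shown sits. That single step gives a direction for one change but no trend that can be carried over to hydrogen. No step beyond the scatter is therefore expected in this assay, although the uncertainty is wide. The expected change is a 1.1-fold higher number from compound 2 to compound 3 (0.04 log units; within the scatter). For compound 3 the estimated value is 25000 nM, with an expected range of 7000 nM to 100000 nM.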

Compound 3, half-maximal effective concentration: 17000 nM
Compound 3: middle estimate off by 1.5-fold (0.17 log units), on the high side, and the stated range covers the measured number.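

In this assay, the propargyl group of compound 2 can be cut back to the methyl group of compound 3 with no real effect: a 1.4-fold lower number from compound 2 to compound 3 (0.13 log units; within the scatter). At this place, therefore, the triple bond is not needed for the activity seen, and ethynyl and hydrogen on the saturated chain carbon bound to the aromatic oxygen cannot be told apart. Hydrogen in place of pentyl gives a much larger step, an at least 11-fold lower number from compound 1 to compound 3 (1.07 log units; beyond the scatter), so the two short groups now agree in standing clearly apart from the longer chain of compound 1, though the true size of this step stays unknown since it starts from a limit of the assay rather than a number: the limit of > 200000 nM in this assay, at which 1 of the 3 values shown sits.

What an ethyl or butyl group would give at this place remains open, so the compounds shown do not tell where between the short groups and the longer chain the activity is lost. Also open, as far as these compounds go, is whether a chain ending in an amine or a carboxylic acid would shift the number at all, in either direction.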